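Oxazoline carbamates: inverting the ring stereocentre

This account rests on a few compounds, and the source may have more. Where it says the series, first, only, none or still open, it means among the compounds named here.

Measured so far:
compound 1 `O=C(NC1CCCCC1)Oc1cccc(C2=NCCO2)c1` gives 22% in an assay on membranes from cerebellum (strain Wistar) for inhibition of Monoglyceride lipase (Rattus norvegicus), read by HPLC, tested at 100 uM; on this read-out lower numbers stand for less inhibition and higher numbers for more inhibition at the one concentration tested (going by the name of the read-out)
compound 2 `CC1(C)COC(c2cccc(OC(=O)NC3CCCCC3)c2)=N1` gives 20% in this assay
compound 3 `C[C@H]1COC(c2cccc(OC(=O)NC3CCCCC3)c2)=N1` gives 28% in this assay

Compound 3 holds the highest of the three numbers, but its nearest neighbour is compound 1, with a number 6 percentage points higher from compound 1 to compound 3 (within the scatter), and its furthest is compound 2, with a number 8 percentage points higher from compound 2 to compound 3 (within the scatter); both steps lie within the scatter, so no ordering among the three can be read from them.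

Compound 4 `C[C@@H]1COC(c2cccc(OC(=O)NC3CCCCC3)c2)=N1` is the next entry. Against compound 3 the change is: the two compounds have the same atoms and bonds and differ only in configuration as drawn: 1 of 1 stereo elements differ; a stereocentre at a saturated ring carbon is drawn S in compound 3 and R in compound 4.

Within the data shown here, no measured step changes configuration alone. The steps that touch the same ring, a number 2 percentage points lower from compound 1 to compound 2 (within the scatter), a number 6 percentage points higher from compound 1 to compound 3 (within the scatter) and a number 8 percentage points higher from compound 2 to compound 3 (within the scatter), are all within the scatter, so nothing among them points to a step beyond the scatter in this assay for this change either. Compound 4 is therefore expected near the measured cluster, estimated at 24% with a range of 12% to 36%. The step of a number 4 percentage points lower from compound 3 to compound 4 (within the scatter) is the expectation, not a measurement.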

Compound 4, a percentage reported as inhibition, at one concentration (the size of the read-out at that concentration, not a potency): 16%
Compound 4: middle estimate off by 8 percentage points, on the high side; the measured number falls inside the stated range.
By their numbers in this assay, from the lowest: compounds 4, 2, 1 and 3 (each within the scatter of the next, the first and the last beyond it).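

In this assay, among these compounds, the stereocentre at the saturated ring carbon gives the only step printed beyond the scatter, a number 12 percentage points lower from compound 3 to compound 4 (beyond the scatter), and this step can be read as one of configuration alone: the fact that compounds 3 and 4 differ only in the configuration as drawn. Methyl in place of hydrogen on a saturated ring carbon in the R form gives a number 6 percentage points lower from compound 1 to compound 4 (within the scatter), and the exchange of the ring group gives a number 4 percentage points lower from compound 2 to compound 4 (within the scatter). The two configurations therefore separate from each other, yet neither separates from compound 1 or compound 2, so the methyl position shows a sensitivity to configuration only in this one pair.

The compounds shown leave open whether an ethyl or a phenyl group at that ring carbon would widen the gap between the two configurations. They also leave open whether a gap seen at one concentration would carry over to a potency.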